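The compounds below may be only part of what the source reports. "The series", "measured", "known", "first", "only" and "open" are said of these compounds alone.

Working notes on the series in a functional assay on A549 cells (Homo sapiens) for cytotoxicity, read by MTT assay, with a stated time of 48 h; on this read-out lower numbers stand for stronger inhibition and higher numbers for weaker inhibition. Of the compounds shown here, two sharing one core have been measured so far. Compound 1 (`C=C1CCC[C@]2(C)CCC(c3cn(-c4cccc([N+](=O)[O-])c4)nn3)=CC[C@@]12C`) gives 24700 nM, and compound 2 (`C=C1CCC[C@]2(C)CCC(c3cn(-c4ccc(Cl)cc4)nn3)=CC[C@@]12C`) gives 20100 nM. The measured step is a 1.2-fold lower number from compound 1 to compound 2 (0.09 log units; within the scatter), so compound 2 stands level with compound 1 on these numbers and holds no real lead.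

The next compound is compound 3 (`C=C1CCC[C@]2(C)CCC(c3cn(-c4ccc(C)cc4)nn3)=CC[C@@]12C`), and the change from compound 2 is methyl in place of chloro on an aromatic carbon. This places methyl in place of chloro on an aromatic carbon, para to a large group, turning 4-chlorophenyl into 4-methylphenyl.

Among the compounds with values here, only one measured step bears on this change, and it is an indirect guide, since it replaces the whole aryl group and never tests methyl against chloro. With that wider swap, compound 2 stayed at 20100 nM, so no shift beyond the scatter is expected here, in either direction. The expected step is a 1.1-fold higher number from compound 2 to compound 3 (0.04 log units; within the scatter). For compound 3 the estimated value is 22000 nM, with an expected range of 12000 nM to 40000 nM.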

Compound 3, half-maximal inhibitory concentration: 58800 nM
Compound 3: the middle estimate sits 2.7-fold (0.43 log units) below what was measured; measured number outside the range, above it.
By their numbers in this assay, from the lowest: compounds 2 and 1 (each within the scatter of the next); then compound 3.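

In this assay, within the data shown here, the place para to a large group on the six-membered aromatic ring proves sensitive to its substituent: methyl in place of chloro gives a 2.9-fold higher number from compound 2 to compound 3 (0.47 log units; beyond the scatter) and is the first single-atom change to go beyond the scatter. Replacing the whole aryl group is not neutral either, since 4-methylphenyl in place of 3-nitrophenyl gives a 2.4-fold higher number from compound 1 to compound 3 (0.38 log units; beyond the scatter) even though compound 1 and compound 2 stand level, which leaves compound 3 as the weakest of the three on these numbers. No measurement at hand accounts for the loss seen with the methyl group.

The compounds shown leave open whether fluoro or bromo at this place would hold the number near that of compound 2, and whether a methoxy group or an amine would move it further up or bring it back down. They also leave open whether methyl in place of chloro would give a step of like size if the shared core were changed.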